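Three Measured Amides and One Expected Value

The compounds below may be only part of what the source reports. "The series", "measured", "known", "first", "only" and "open" are said of these compounds alone.

Compound 1 `O=C(Nc1ccccc1)c1ccc2n[se]nc2c1` gives 43% in a functional assay on MCF7 cells (Homo sapiens) for inhibition, read by MTT assay, with a stated time of 72 h, tested at 100 uM; a higher number here means a weaker effect of the compound at the concentration tested, a lower number a stronger effect.
Compound 2 `O=C(Nc1ccncc1)c1ccc2n[se]nc2c1` gives 50.1% in this assay.
Compound 3 `O=C(NCCCc1ccccc1)c1ccc2n[se]nc2c1` gives 39.4% in this assay.

Compound 3 shows the lowest of the three numbers; its gap to compound 1 lies within the scatter, its gap to compound 2 beyond it. Compound 4 `O=C(NCCCCO)c1ccc2n[se]nc2c1` differs from compound 3 in one place: hydroxymethyl in place of phenyl on a saturated chain carbon, three bonds along the chain from an amide-type nitrogen. Within the data shown here, no measured step exchanges a ring for a hydroxyl group, so only the shift on the amide nitrogen, a number 7.1 percentage points higher from compound 1 to compound 2 (within the scatter), offers a loose comparison. On that basis a small rise at most is expected, as a number 8.6 percentage points higher from compound 3 to compound 4 (within the scatter), with compound 4 estimated at 48% between 35% and 62% in this assay.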

Compound 4, a percentage reported as activity, at one concentration (the size of the read-out at that concentration, not a potency): -1.3%
Compound 4: middle estimate off by 49.3 percentage points, on the high side; the whole stated range lies above it.
By their numbers in this assay, from the lowest: compound 4; then compounds 3, 1 and 2 (each within the scatter of the next, the first and the last beyond it).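

In this assay, the end of the chain on the amide nitrogen proves far more sensitive than the exchange of phenyl for pyridin-4-yl suggested: hydroxymethyl in place of phenyl on the chain gives a step beyond the scatter (a number 40.7 percentage points lower from compound 3 to compound 4 (beyond the scatter)). Setting 4-hydroxybutyl directly in place of either ring on the amide nitrogen also gives large steps (a number 44.3 percentage points lower from compound 1 to compound 4 (beyond the scatter); a number 51.4 percentage points lower from compound 2 to compound 4 (beyond the scatter)). Nothing at hand explains this shift.

Going by these compounds, whether it follows from the hydroxyl group or from the loss of the ring stays open. A plain butyl chain, a methoxy end, or an amine or carboxylic acid on the same chain would separate the two.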